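Piperazin-1-yl for tert-butyl: tolerance notes

A few compounds are considered here, and "the series" means these few. Any claim that something is new, unique, unknown or untested is made for them only; others in the source may bear on it.

Measured in an ADME assay on HepG2 cells (Homo sapiens) for cytotoxicity; a higher number here means that more compound is tolerated, a lower number that less compound is tolerated:
- compound 1 `Fc1cccc(COc2ccc(Nc3ncnc4cc(C#CCN5CCNCC5)sc34)cc2Cl)c1`: > 29 uM (a limit)
- compound 2 `CC(C)(C)CC#Cc1cc2c(Nc3ccc(OCc4cccc(F)c4)c(Cl)c3)ncnc2s1`: > 32 uM (a limit)

Compound 2 stands at > 32 uM, which is a limit and not a number. Compound 1 stands at > 29 uM, which is also a limit. For the measured compounds named here, no measured compound therefore has a numerical half-maximal toxic concentration, and no step between measured compounds is available.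

The next compound is compound 3 `Fc1cccc(COc2ccc(Nc3ncnc4sc(C#CCN5CCNCC5)cc34)cc2Cl)c1`. Relative to compound 2, piperazin-1-yl stands in place of tert-butyl on a saturated chain carbon bound to a triple-bonded carbon (piperazin-1-yl in place of tert-butyl on a saturated chain carbon bound to a triple-bonded carbon).

In this assay the expected step of an at least 1.0-fold lower number from compound 2 to compound 3 (0.02 log units; that floor lies within the scatter) is none beyond the scatter, though a lower reading would not be surprising. Compound 3 is expected at 30 uM, with an estimated range of 12 uM to 60 uM.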

Compound 3, half-maximal toxic concentration: 7.7 uM
The estimate for compound 3 lay 3.9-fold (0.59 log units) above the measured number, outside the stated range (below it).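

Piperazin-1-yl in place of tert-butyl on a saturated chain carbon bound to a triple-bonded carbon gives an at least 4.1-fold lower number from compound 2 to compound 3 (0.61 log units; beyond the scatter) in this assay, so the group at this position matters for tolerance. For the compounds shown here, compound 3 also gives the first reading that is a number and not a limit. Compound 1, which carries the same 3-(piperazin-1-yl)prop-1-yn-1-yl group on its own core, stands at > 29 uM as a limit.

No measured property shown accounts for the step. On these data alone, whether a morpholin-4-yl group, a dimethylamino group or a longer chain in the same place would keep the lower number or return it to the level of compound 2 remains open.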